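This account rests on a few compounds, and the source may have more. Where it says the series, first, only, none or still open, it means among the compounds named here.

Compound 3 `NCCSCCc1c[nH]c2ccc(F)cc12` gives 4 nM in an assay on isolated protein (urine) for inhibition of Myeloperoxidase (Homo sapiens), with a stated time of 5 min; on this read-out lower numbers stand for stronger inhibition and higher numbers for weaker inhibition. Among the three measured compounds its number is the lowest; compound 2 `NCCCCc1c[nH]c2c(F)cccc12`, with 6 nM, sits within the scatter of it, while compound 1 `NCCCc1c[nH]c2c(F)cccc12`, with 24 nM, sits beyond it. Compound 4 `CCSCCc1c[nH]c2ccc(F)cc12` differs from compound 3 by hydrogen in place of amino on a saturated chain carbon, two bonds along the chain from a sulfur. Among the compounds with values here, no measured step removes the amino altogether; the only recorded step, a 4.0-fold lower number from compound 1 to compound 2 (0.60 log units; beyond the scatter), concerns a different alteration of the chain and so bears on this change only loosely. With the amino gone outright, a step well beyond the scatter toward weaker inhibition is expected for compound 4, namely a 500-fold higher number from compound 3 to compound 4 (2.70 log units; beyond the scatter). Compound 4 is therefore estimated at 2000 nM, with a range from 200 nM to 20000 nM.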

Compound 4, half-maximal inhibitory concentration: > 100 nM
Compound 4: no number, only a limit; the forecaster's own chance of this, stated with the estimate: 25%; the middle value lies beyond the limit too.
By their numbers in this assay, from the lowest: compounds 3 and 2 (each within the scatter of the next); then compound 1. At a limit, above all of these: compound 4.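

Within the data shown here, for the first time the amino itself is changed, not the chain that carries it. In this assay, hydrogen in place of amino on a saturated chain carbon, two bonds along the chain from a sulfur, gives an at least 25-fold higher number from compound 3 to compound 4 (1.39 log units; beyond the scatter), so the amino matters strongly at this position. The true size of this step stays unknown, since the reading for compound 4 is a limit and not a number: the limit of > 100 nM in this assay, at which 1 of the 4 values shown sits.

Going by these compounds, whether a hydroxyl or a dimethylamino group at this position would keep the number near that of compound 3 remains open. So does whether losing the amino from the all-carbon chain of compound 2 would have a similar effect.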